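Two methyl groups return to the phenyl ring

The compounds below may be only part of what the source reports. "The series", "measured", "known", "first", "only" and "open" are said of these compounds alone.

Compound 1 `Cc1cc(Cl)ccc1NC(=O)Nc1nc(Sc2c[nH]c3ccccc23)cc(N2CCN(Cc3ccccc3)CC2)n1` — 22100 nM
Compound 2 `O=C(Nc1ccccc1)Nc1nc(NC2CC2)cc(Sc2c[nH]c3ccccc23)n1` — 7860 nM
Compound 3 `O=C(Nc1ccccc1)Nc1nc(Sc2c[nH]c3ccccc23)cc(N2CCN(Cc3ccccc3)CC2)n1` — 10200 nM

In a functional assay on MDA-MB-231 cells (Homo sapiens) for inhibition, with a stated time of 72 h (on this read-out higher numbers stand for weaker inhibition and lower numbers for stronger inhibition), compound 3 gives 10200 nM, the second highest of the three numbers. Compound 2 gives 7860 nM, within the scatter of compound 3, so no order between the two can be read. Compound 1 gives 22100 nM, and the one measured step that joins two of these compounds is a 2.2-fold lower number from compound 1 to compound 3 (0.34 log units; beyond the scatter).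

Compound 4 `Cc1ccc(C)c(NC(=O)Nc2nc(Sc3c[nH]c4ccccc34)cc(N3CCN(Cc4ccccc4)CC3)n2)c1` has not yet been measured. It differs from compound 3 in one place: 2,5-dimethylphenyl in place of phenyl on an amide-type nitrogen. The step from compound 1 to compound 3 is the only one that bears on this change, since it also alters the substitution of the phenyl on the amide-type nitrogen, there by taking away a chloro and a methyl group. Compound 4 moves the other way, putting two methyl groups onto that phenyl. On that basis a modest step towards a higher number in this assay is expected for compound 4, of roughly the size seen from compound 1 to compound 3 but not certain to clear the scatter.

Compound 4 is therefore estimated at 16000 nM, in the range 7000 nM to 36000 nM, a step of a 1.6-fold higher number from compound 3 to compound 4 (0.20 log units; within the scatter).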

Compound 4, half-maximal inhibitory concentration: 19000 nM
Compound 4: middle estimate off by 1.2-fold (0.07 log units), on the low side, within the range that was stated.
By their numbers in this assay, from the lowest: compounds 2, 3, 4 and 1 (each within the scatter of the next, the first and the last beyond it).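

In this assay, placing 2,5-dimethylphenyl on the amide-type nitrogen in place of phenyl gives a step that stays within the scatter (a 1.9-fold higher number from compound 3 to compound 4 (0.27 log units; within the scatter)), so this change alone cannot be said to alter the read-out, even though the earlier step involving 4-chloro-2-methylphenyl and phenyl lay beyond it (a 2.2-fold lower number from compound 1 to compound 3 (0.34 log units; beyond the scatter)). The two substituted phenyl groups also cannot be told apart, since exchanging 4-chloro-2-methylphenyl for 2,5-dimethylphenyl likewise stays within the scatter (a 1.2-fold lower number from compound 1 to compound 4 (0.07 log units; within the scatter)), and compound 4 therefore sits within the scatter of both compound 1 and compound 3. Nothing given here accounts for these numbers.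

The compounds shown carry only methyl and chloro groups on this phenyl, which leaves open how a methoxy group, an amine or a carboxylic acid would read at the same place. Also open, on these data alone, is whether a single methyl group or a single chloro on the phenyl would give a step that clears the scatter.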